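The source may hold more compounds than are shown below. What is called first, only, known or untested is meant among the compounds shown, and "the series" means these compounds.

Working notes on the series in a functional assay on NCI-H460 cells (Homo sapiens) for cytotoxicity, read by MTT assay, with a stated time of 72 h; a lower number here means a stronger inhibitor, a higher number a weaker inhibitor. Compound 1 `CC1CCN(Cc2ccc3nc(NC(=O)N/N=C/c4cn(Cc5cccc(Cl)c5)c5ccccc45)sc3c2)CC1` gives 280 nM, compound 2 `CCN(CC)Cc1ccc2nc(NC(=O)N/N=C/c3cn(Cc4cccc(Cl)c4)c4ccccc34)sc2c1` gives 220 nM and compound 3 `CN(C)Cc1ccc2nc(NC(=O)N/N=C/c3cn(Cc4cccc(Cl)c4)c4ccccc34)sc2c1` gives 420 nM. Compound 2 cannot be separated from the other two: a 1.3-fold lower number from compound 1 to compound 2 (0.10 log units; within the scatter) and a 1.9-fold higher number from compound 2 to compound 3 (0.28 log units; within the scatter), while a 1.5-fold higher number from compound 1 to compound 3 (0.18 log units; within the scatter).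

Compound 4 `CCN(CC)Cc1ccc2nc(NC(=O)N/N=C/c3cn(Cc4ccccc4)c4ccccc34)sc2c1` keeps the diethylamino group of compound 2 and differs from it in one place, with hydrogen in place of chloro on an aromatic carbon, so that 3-chlorobenzyl becomes benzyl: hydrogen in place of chloro on an aromatic carbon. All three measured steps exchange the amino group on the saturated chain carbon, and none touches the chloro. They therefore bear on this change only indirectly, and the data hold no direct measure of it.

On these data alone, no step beyond the scatter is expected in this assay, and the direction remains open. The estimated size is a 1.3-fold higher number from compound 2 to compound 4 (0.10 log units; within the scatter). For compound 4 the expected value is 280 nM, with an estimated range of 110 nM to 700 nM.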

Compound 4, half-maximal inhibitory concentration: 450 nM
The estimate for compound 4 lay 1.6-fold (0.21 log units) below the measured number; the range from low to high includes it.
By their numbers in this assay, from the lowest: compounds 2, 1, 3 and 4 (each within the scatter of the next, the first and the last beyond it).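

In this assay the series shows a 2.0-fold higher number from compound 2 to compound 4 (0.31 log units; beyond the scatter) with hydrogen in place of chloro on the aromatic carbon, so that 3-chlorobenzyl becomes benzyl. Among the compounds shown here, this is the first single change to pass the scatter, as the three exchanges of the amino group all stayed within it. It is a modest step, it rests on this one pair with the diethylamino group held fixed, and nothing available accounts for it.

On these data alone, whether a fluoro, methoxy or trifluoromethyl group in place of the chloro would keep the number of compound 2 remains open. Also open, as far as these compounds go, is whether the same change would give a similar step with dimethylamino or 4-methylpiperidin-1-yl on the saturated chain carbon.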